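Methylcarbamoyl in place of 2-aminophenyl on the amide-type nitrogen

This account rests on a few compounds, and the source may have more. Where it says the series, first, only, none or still open, it means among the compounds named here.

Working notes on three measured compounds that share one core and differ in the group on a carbonyl carbon. In a functional assay on blood (Homo sapiens), with a stated time of 60 min, in the presence of a further agent that is not named here (a lower number here means that less compound is needed, a higher number that more compound is needed for the effect), compound 1 (`COC(=O)C1(S(=O)(=O)c2ccc(Oc3ccc(OC(F)(F)F)cc3)cc2)CCC2(CCNCC2)C1`), with methoxy in that place, gives > 15000 nM, which is a limit of the assay and not a number. Compound 2 (`NC(=O)C1(S(=O)(=O)c2ccc(Oc3ccc(OC(F)(F)F)cc3)cc2)CCC2(CCNCC2)C1`), with amino, gives 3700 nM. Going by the values given here, compound 3 (`Nc1ccccc1NC(=O)C1(S(=O)(=O)c2ccc(Oc3ccc(OC(F)(F)F)cc3)cc2)CCC2(CCNCC2)C1`), with (2-aminophenyl)amino, gives 900 nM, the lowest number so far in this assay.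

Next is compound 4 (`CNC(=O)NC(=O)C1(S(=O)(=O)c2ccc(Oc3ccc(OC(F)(F)F)cc3)cc2)CCC2(CCNCC2)C1`), with methylcarbamoyl in place of 2-aminophenyl on an amide-type nitrogen. The closest evidence is a 4.1-fold lower number from compound 2 to compound 3 (0.61 log units; beyond the scatter), since that step adds the group that now leaves. The other steps, an at least 4.0-fold lower number from compound 1 to compound 2 (0.60 log units; beyond the scatter) and an at least 16-fold lower number from compound 1 to compound 3 (1.22 log units; beyond the scatter), show that this part of the structure moves the number. Among the compounds with values here, no measured compound carries methylcarbamoyl, so the reading is uncertain. Part or most of the gain seen from the 2-aminophenyl group in compound 3, at 900 nM, is expected to be lost, with a modest step toward a higher number in this assay. The expected step is a 2.8-fold higher number from compound 3 to compound 4 (0.44 log units; beyond the scatter). For compound 4 the estimated value is 2500 nM, with an expected range of 700 nM to 9000 nM.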

Compound 4, half-maximal effective concentration: < 400 nM
Compound 4: no number, only a limit (the forecaster's own chance of this, stated with the estimate: 15%); middle value at least 6.2-fold (0.79 log units) away from the limit.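

In this assay compound 4 gives a limit of the assay and not a number, so its steps fix only a minimum size: the limit of < 400 nM in this assay, at which 1 of the 4 values shown sits.

Even so, the replacement gives an at least 2.2-fold lower number from compound 3 to compound 4 (0.35 log units; beyond the scatter), which shows that a six-membered aromatic ring on this amide-type nitrogen is not needed for a low number, as methylcarbamoyl has no ring; until now, 2-aminophenyl was the only group seen in this place. Going by these compounds alone, the gain over the unsubstituted amide also grows, with methylcarbamoyl in place of hydrogen giving an at least 9.2-fold lower number from compound 2 to compound 4 (0.96 log units; beyond the scatter), and the change from methoxy on the carbonyl carbon gives an at least 37-fold lower number from compound 1 to compound 4 (1.57 log units; beyond the scatter), so this position moves the number further than the earlier compounds could show.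

As far as these compounds go, how far compound 4 lies past its limit stays open, and with it the true size of all three steps. Also open, from the compounds shown here alone, is which part of methylcarbamoyl goes with the lower number, and an acetyl group, a plain carbamoyl group or an ethylcarbamoyl group on the same nitrogen would bear on that question.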